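Diamino quinoxaline analogues: phenoxy to benzylamino

The compounds below may be only part of what the source reports. "The series", "measured", "known", "first", "only" and "open" are said of these compounds alone.

Measured compounds:
compound 1, `CCOC(=O)[C@H](CCC(=O)O)NC(=O)c1ccc(Sc2nc3cc(N)cc(N)c3nc2-c2ccccc2)cc1`: < 100000 nM
compound 2, `Nc1cc(N)c2nc(-c3ccccc3)c(Oc3ccc(F)cc3)nc2c1`: 33100 nM
compound 3, `CCOC(=O)[C@H](CCC(=O)O)NC(=O)c1ccc(CNc2nc3cc(N)cc(N)c3nc2-c2ccccc2)cc1`: < 100000 nM

Within the data shown here, in a functional assay on ACHN cells (Homo sapiens) for inhibition, read by sulforhodamine B assay, with a stated time of 48 h (a lower number here means a stronger inhibitor of growth, a higher number a weaker inhibitor of growth), compound 2, `Nc1cc(N)c2nc(-c3ccccc3)c(Oc3ccc(F)cc3)nc2c1`, gives 33100 nM, the only number among the three values shown. For compound 1 the value < 100000 nM is a limit of the assay, not a number. For compound 3 the value < 100000 nM is likewise a limit. Compound 4, `Nc1cc(N)c2nc(-c3ccccc3)c(NCc3ccc(F)cc3)nc2c1`, is not yet measured; it differs from compound 2 by (4-fluorobenzyl)amino in place of 4-fluorophenoxy on an aromatic carbon. Among the measured compounds shown here, no measured step connects two compounds of this set, so the size of the change cannot be read from the data; the step of a 1.4-fold higher number from compound 2 to compound 4 (0.13 log units; within the scatter) is expected to lie within the scatter or to weaken inhibition slightly, since the limit of < 100000 nM in this assay, at which 2 of the 3 values shown sit, shows how often this series reaches only a limit. Compound 4 is estimated at 45000 nM, between 12000 nM and 100000 nM.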

Compound 4, concentration for total growth inhibition: 3090 nM
Beside the measured number, compound 4's estimate is 15-fold (1.16 log units) above it; the measured number lies below the stated range.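

In this assay, among these compounds, (4-fluorobenzyl)amino in place of 4-fluorophenoxy gives the first readable step of the set: an 11-fold lower number from compound 2 to compound 4 (1.03 log units; beyond the scatter). The aromatic carbon next to the ring nitrogen and ortho to a phenyl group therefore responds strongly to this change, well beyond the scatter. Nothing shown here gives a cause for the size of this step. The change swaps the linking oxygen for nitrogen and also adds a carbon, and these two effects remain unseparated. A 4-fluoroanilino or a 4-fluorobenzyloxy group at this position would tell them apart, and the compounds shown leave that open.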